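This account rests on a few compounds, and the source may have more. Where it says the series, first, only, none or still open, it means among the compounds named here.

Three compounds with a shared core differ only in the aryl group on an amide-type nitrogen. In a functional assay on SMMC-7721 cells (Homo sapiens) for inhibition, read by MTT assay, with a stated time of 48 h (a lower number here means a stronger inhibitor, a higher number a weaker inhibitor), compound 1 `Cc1ccc(NC(=O)Nc2cccc(-c3cccc4[nH]nc(N)c34)c2)cc1` gives 4450 nM, compound 2 `Nc1n[nH]c2cccc(-c3cccc(NC(=O)Nc4ccc(Cl)cc4Cl)c3)c12` gives 1900 nM and compound 3 `CC(C)c1cccc(NC(=O)Nc2cccc(-c3cccc4[nH]nc(N)c34)c2)c1` gives 280 nM. Compound 3 therefore has the lowest number of the three and is the strongest inhibitor in this small set.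

Compound 4 `COc1cccc(NC(=O)Nc2cccc(-c3cccc4[nH]nc(N)c34)c2)c1` changes one group of compound 3: methoxy in place of isopropyl on an aromatic carbon. In words, methoxy takes the place of isopropyl on an aromatic carbon, meta to a large group.

Within the data shown here, no measured step makes this exact change, and no measured compound carries methoxy. The closest evidence comes from swaps of the whole aryl group. Moving to 3-isopropylphenyl gave a 16-fold lower number from compound 1 to compound 3 (1.20 log units; beyond the scatter), a large step, and a 6.8-fold lower number from compound 2 to compound 3 (0.83 log units; beyond the scatter), a modest one. Moving to 2,4-dichlorophenyl gave a 2.3-fold lower number from compound 1 to compound 2 (0.37 log units; beyond the scatter), also modest. The number clearly responds to this group, and compound 3 sits at the low end, so losing isopropyl is more likely to raise the number than to lower it. A modest step is the reasonable expectation. In this assay the expected step is a 3.0-fold higher number from compound 3 to compound 4 (0.48 log units; beyond the scatter). For compound 4 the estimated value is 850 nM, with an expected range of 250 nM to 3000 nM.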

Compound 4, half-maximal inhibitory concentration: 2860 nM
For compound 4 the middle estimate is 3.4-fold (0.53 log units) below the measured one, within the range that was stated.
By their numbers in this assay, from the lowest: compound 3; then compounds 2, 4 and 1 (each within the scatter of the next, the first and the last beyond it).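

In this assay, keeping the aryl ring and the place on it while exchanging only isopropyl for methoxy gives a 10-fold higher number from compound 3 to compound 4 (1.01 log units; beyond the scatter), so this position, meta to a large group, responds strongly to a single change of group, something the earlier swaps of the whole aryl group could not show. The low number of compound 3 also proves to depend on isopropyl itself and not merely on having a group at this place: a 1.5-fold higher number from compound 2 to compound 4 (0.18 log units; within the scatter) and a 1.6-fold lower number from compound 1 to compound 4 (0.19 log units; within the scatter) both lie within the scatter, so with methoxy the compound falls in with the two weaker aryl variants. Nothing measured in this set explains why the step is this large.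

As far as these compounds go, how ethyl, tert-butyl or an amine would fare at the same place stays open, so it cannot yet be said whether isopropyl is a rare good fit or methoxy a particularly poor one. From the compounds shown here alone, how isopropyl or methoxy would read on another carbon of that ring also stays open.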